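The source may hold more compounds than are shown below. What is called first, only, known or untested is meant among the compounds shown, and "the series" means these compounds.

Working notes on the series in a functional assay on cells (Tumor Cell line, Homo sapiens) for cytotoxicity (on this read-out lower numbers stand for stronger inhibition and higher numbers for weaker inhibition), follow. Going by the values given here, compound 1 (`CN(C)Cc1cc(C(=O)/C=C/c2ccc(Cl)cc2)cc(CN(C)C)c1O`) gives 10000 nM as the higher of the two numbers so far, and compound 2 (`CN(C)Cc1cc(C(=O)/C=C/c2ccc(Cl)cc2Cl)cc(CN(C)C)c1O`) gives 3090 nM as the lower. Among the compounds with values here, the only measured step (a 3.2-fold lower number from compound 1 to compound 2 (0.51 log units; beyond the scatter)) is a modest one, with chloro in place of hydrogen on an aromatic carbon.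

Compound 3 (`Cc1ccc(/C=C/C(=O)c2cc(CN(C)C)c(O)c(CN(C)C)c2)cc1`) is not yet measured. Its difference from compound 1 (methyl in place of chloro on an aromatic carbon) is methyl in place of chloro on an aromatic carbon, para to a large group, that is, 4-chlorophenyl to 4-methylphenyl. Within the data shown here, no measured step exchanges these two groups, so the evidence is indirect. Compound 2 and its step (a 3.2-fold lower number from compound 1 to compound 2 (0.51 log units; beyond the scatter)) show only that one added chloro went with a modest shift, and they give no direction for methyl. In this assay a change no larger than that is therefore expected, most likely none beyond the scatter, with the direction open. The expected step (a 1.1-fold lower number from compound 1 to compound 3 (0.05 log units; within the scatter)) is small. The estimate for compound 3 is 9000 nM as the expected middle, with an expected range from 4000 nM to 20000 nM for repeat measurements.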

Compound 3, half-maximal inhibitory concentration: 17800 nM
Compound 3: the middle estimate sits 2.0-fold (0.30 log units) below what was measured, and the stated range covers the measured number.
By their numbers in this assay, from the lowest: compound 2; then compounds 1 and 3 (each within the scatter of the next).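

Going by these compounds alone, with methyl in place of chloro on an aromatic carbon, para to a large group, this assay gives the first direct reading at this position (a 1.8-fold higher number from compound 1 to compound 3 (0.25 log units; within the scatter)), and 4-chlorophenyl and 4-methylphenyl are not told apart on it. The step from the 2,4-dichlorophenyl group to the 4-methylphenyl group is of another size (a 5.8-fold higher number from compound 2 to compound 3 (0.76 log units; beyond the scatter)), so compound 2 now stands alone at the low end of the three, with its steps to compound 1 and to compound 3 both beyond the scatter. Nothing available bears on the reason for these numbers, so the series remains a bare record of values.

The compounds shown leave open whether this position reads differently with a group other than chloro or methyl, such as a methoxy group, an amine or a carboxylic acid, or with plain hydrogen. Also open, from the compounds shown here alone, is whether fluoro or bromo in place of the added chloro of compound 2 would keep the lower number, and whether a second methyl on that aromatic ring would go the same way.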